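Fluoro added to the terminal phenyl of compound 3

The source may report more compounds than this note shows. Statements on the series, on what has been measured and on what is new or still open speak of the compounds shown alone.

Three compounds sharing one core were measured in a functional assay on A549 cells (Homo sapiens) for antiproliferative activity, read by MTT assay, with a stated time of 24 h; on this read-out higher numbers stand for weaker inhibition and lower numbers for stronger inhibition. Compound 1 `O=c1[nH]cc(S(=O)(=O)Nc2ccccc2-c2cn(-c3ccccc3)nn2)c(=O)[nH]1` gives 6790 nM in this assay, compound 2 `O=c1[nH]cc(S(=O)(=O)Nc2ccccc2-c2cn(-c3ccccc3Cl)nn2)c(=O)[nH]1` gives 2740 nM, and compound 3 `O=c1[nH]cc(S(=O)(=O)Nc2cccc(-c3cn(-c4ccccc4)nn3)c2)c(=O)[nH]1` gives 12700 nM. Compound 3 stands highest of the three numbers: its gap to compound 1 lies within the scatter, while its gap to compound 2 lies beyond it. Within the data shown here, the single step between close neighbours, a 2.5-fold lower number from compound 1 to compound 2 (0.39 log units; beyond the scatter), is modest and lowers the number.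

Compound 4 `O=c1[nH]cc(S(=O)(=O)Nc2cccc(-c3cn(-c4ccccc4F)nn3)c2)c(=O)[nH]1` differs from compound 3 by fluoro in place of hydrogen on an aromatic carbon, a fluoro in place of hydrogen on an aromatic carbon of a six-membered aromatic ring of carbon only, ortho to a large group; one bond further out this reads phenyl to 2-fluorophenyl. The only step that bears on it is the one from compound 1 to compound 2, where a halogen entered the same place on the other series and lowered the number modestly. Here the halogen is fluoro rather than chloro, so a smaller change is expected. Compound 4 is therefore expected to show a modest lowering, a 1.7-fold lower number from compound 3 to compound 4 (0.23 log units; within the scatter), in this assay. The estimate for compound 4 is 7500 nM, with a range from 3000 nM to 18000 nM.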

Compound 4, half-maximal inhibitory concentration: > 20000 nM
Compound 4: a limit, no number; the forecaster's own chance of this, stated with the estimate: 5%; middle value at least 2.6-fold (0.42 log units) away from the limit.
By their numbers in this assay, from the lowest: compound 2; then compounds 1 and 3 (each within the scatter of the next). At a limit, above all of these: compound 4.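

On the core of compound 3, fluoro in place of hydrogen on an aromatic carbon, ortho to a large group, brought no lowering of the number in this assay, and the step reads an at least 1.5-fold higher number from compound 3 to compound 4 (0.19 log units; that floor lies within the scatter). From the compounds shown here alone, compound 4 gives > 20000 nM, which is a limit of the assay and not a number, so the full size of this step stays unknown: the limit of > 20000 nM in this assay, at which 1 of the 4 values shown sits. The only earlier halogen step, a 2.5-fold lower number from compound 1 to compound 2 (0.39 log units; beyond the scatter), therefore does not carry over as a general rule for halogen at this kind of place, though those two steps differ both in the halogen and in the compound that carries it, and the shown data cannot separate the two differences.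

The compounds shown leave open whether the outcome belongs to fluoro itself or to the core of compound 3, which a chloro on that same core would help to settle. They also leave open how a methoxy group or an amine at this place on either core would move the number in this assay.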